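Extending the N-alkyl group on the pyrimidinone of compound 2

The source may report more compounds than this note shows. Statements on the series, on what has been measured and on what is new or still open speak of the compounds shown alone.

Compounds measured so far:
compound 1, `CCCCCCCCN(C)C(=O)Cn1cc(Cc2cnc(OCC)nc2)c(=O)nc1SCc1ccc(F)cc1`: 23%
compound 2, `CCCCCCCCN(C)C(=O)Cn1cc(Cc2cnc(=O)n(CC)c2)c(=O)nc1SCc1ccc(F)cc1`: 48%
compound 3, `CCCCCCCCCCCCN(C)C(=O)Cn1cc(Cc2cnc(=O)n(CC(=O)OCC)c2)c(=O)nc1SCc1ccc(F)cc1`: 55%

In a functional assay on a cell-free system (plasma) for inhibition of platelet-activating factor acetylhydrolase (Homo sapiens), tested at 100 nM (a higher number here means more inhibition at the concentration tested (going by the name of the read-out), a lower number less inhibition), compound 2 gives 48%, which is the second highest of the three numbers. Compound 3 lies nearest to it, within the scatter, while compound 1 lies furthest below it, beyond the scatter. Going by the values given here, the one single-point step among the measured compounds is a number 25 percentage points higher from compound 1 to compound 2 (beyond the scatter), and it concerns the aromatic group on the saturated chain carbon bound to an aromatic carbon, not the part of the molecule that changes here.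

Compound 4, `CCCCCCCCN(C)C(=O)Cn1cc(Cc2cnc(=O)n(CC(=O)NC)c2)c(=O)nc1SCc1ccc(F)cc1`, is yet to be measured. It differs from compound 2 by methylcarbamoyl in place of methyl on a saturated chain carbon bound to an aromatic nitrogen. Among the compounds with values here, no measured step covers this change alone. Compound 3 carries an ester at the same place together with a longer chain, and its value stands within the scatter of compound 2, so the two measured compounds with different groups at this position show no separation. Compound 4 is therefore expected to stay close to compound 2, with a step of a number 2 percentage points higher from compound 2 to compound 4 (within the scatter) that does not reach beyond the scatter. The estimate for compound 4 in this assay is 50%, ranging from 30% to 70%.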

Compound 4, a percentage reported as inhibition, at one concentration (the size of the read-out at that concentration, not a potency): 63%
Estimate against measurement, compound 4: 13 percentage points below; the range from low to high includes it.
By their numbers in this assay, from the lowest: compound 1; then compounds 2, 3 and 4 (each within the scatter of the next, the first and the last beyond it).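

In this assay, going by these compounds alone, the step of a number 15 percentage points higher from compound 2 to compound 4 (beyond the scatter) is the first measured change at this position taken on its own, and it shows that this place responds: methylcarbamoyl in place of methyl on a saturated chain carbon bound to an aromatic nitrogen moves the read-out beyond the scatter, something compound 3 could not show, as it also differs in its longer chain. With the change of the whole group on the saturated chain carbon bound to an aromatic carbon, the read-out reaches a number 40 percentage points higher from compound 1 to compound 4 (beyond the scatter) and thus a separation that neither compound 1 nor compound 2 alone had revealed at this position. Nothing measured here accounts for this step.

The compounds shown leave open whether the step belongs to the amide hydrogen or simply to a larger group at this place, and a dimethylamide, a carboxylic acid or a plain propyl chain there would separate these readings. They also leave open whether methylcarbamoyl gives a step of similar size on the longer chain that compound 3 carries.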